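Fluorophenoxy to Fluorophenylsulfanyl: an Unreadable Neighbourhood

The source may hold more compounds than are shown below. What is called first, only, known or untested is meant among the compounds shown, and "the series" means these compounds.

Compound 3 `Nc1cc(N)c2nc(-c3ccccc3)c(Oc3ccc(F)cc3)nc2c1` carries a 4-fluorophenoxy group on the shared core. In a functional assay on LOX IMVI cells (Homo sapiens) for inhibition, read by sulforhodamine B assay, with a stated time of 48 h (on this read-out lower numbers stand for higher toxicity in this test and higher numbers for lower toxicity in this test), compound 3 gives only a limit, < 100000 nM. Its measured relatives are compound 1 `Nc1cc(N)c2nc(-c3ccccc3)c(NCc3ccc(F)cc3)nc2c1`, which in this assay gives 6610 nM, and compound 2 `COc1ccc(Sc2nc3cc(N)cc(N)c3nc2-c2ccccc2)cc1`. In this assay compound 2 likewise gives only a limit, < 100000 nM. The steps a step that the limit leaves unreadable from compound 1 to compound 3 and a step that the two limits leave unreadable from compound 2 to compound 3 cannot be sized because the limit of < 100000 nM in this assay, at which 2 of the 3 values shown sit, hides their end points, and the same holds for the step that the limit leaves unreadable from compound 1 to compound 2.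

Compound 4 `Nc1cc(N)c2nc(-c3ccccc3)c(Sc3ccc(F)cc3)nc2c1` differs from compound 3 in one place: (4-fluorophenyl)sulfanyl in place of 4-fluorophenoxy on an aromatic carbon. Among the compounds with values here, no measured step exchanges oxygen for sulfur at this position; the step from compound 2 to compound 3 does involve a sulfanyl group, but both of its ends sit at the limit. With compound 3 itself at the limit, the expectation for compound 4 rests on little more than that. Compound 4 is expected to fall near 60000 nM, within 8000 nM to 100000 nM, quite possibly again reported only as a limit. The step that the limit leaves unreadable from compound 3 to compound 4 is therefore expected to be small, with no direction the data can support.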

Compound 4, concentration lethal to 50% of the cells: 74100 nM
Estimate against measurement, compound 4: 1.2-fold (0.09 log units) below; the range from low to high includes it.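

In this assay, the position now gives its first readable step: with (4-fluorophenyl)sulfanyl in place of (4-fluorobenzyl)amino on the aromatic carbon, the change produces an 11-fold higher number from compound 1 to compound 4 (1.05 log units; beyond the scatter). Within the data shown here, on this read-out, the higher number means lower toxicity in this test, so the exchange of these two groups has a measurable size, which none of the earlier pairs could show. The steps linking compound 4 to compound 2 and to compound 3 still cannot be read because each has a limit at one end: the limit of < 100000 nM in this assay, at which 2 of the 4 values shown sit.

On these data alone, whether exchanging oxygen for sulfur in the link, or fluoro for methoxy on the sulfanyl ring, changes the number therefore stays open. The compounds shown also leave open how a plain amino group or a longer chain, such as 2-phenylethylamino, would read at this position.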